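Swapping Methoxycarbonyl for Cyano on an Aromatic Carbon

This account rests on a few compounds, and the source may have more. Where it says the series, first, only, none or still open, it means among the compounds named here.

Measured so far in a functional assay on ileum (Cavia porcellus) for antagonist activity; on this read-out higher numbers stand for weaker inhibition and lower numbers for stronger inhibition:
- Compound 1 `CC(=O)c1ccc(OCCCOc2ccc3c(O)c([N+](=O)[O-])c(=O)oc3c2)cc1`: 6100 nM
- Compound 2 `COC(=O)c1ccc(OCCCOc2ccc3c(O)c([N+](=O)[O-])c(=O)oc3c2)cc1`: > 10000 nM (a limit of the assay)

Compound 2 gives > 10000 nM, which is a limit of the assay and not a number. Compound 3 `N#Cc1ccc(OCCCOc2ccc3c(O)c([N+](=O)[O-])c(=O)oc3c2)cc1` has not been measured yet. It carries cyano in place of methoxycarbonyl on an aromatic carbon, para to a large group: cyano in place of methoxycarbonyl on an aromatic carbon. Going by the values given here, one measured step bears on this change, as it also alters the group at that place: an at least 1.6-fold higher number from compound 1 to compound 2 (0.21 log units; that floor lies within the scatter). That step shows no change beyond the scatter. Among the compounds with values here, compound 1, at 6100 nM, is the only number to lean on, so only a small step is expected in this assay, towards a slightly lower number if any. The estimated step is an at least 1.4-fold lower number from compound 2 to compound 3 (0.15 log units; that floor lies within the scatter). For compound 3 the expected value is 7000 nM, with an estimated range of 2000 nM to 20000 nM.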

Compound 3, half-maximal inhibitory concentration: > 10000 nM
Compound 3 gave a limit, no number; the forecaster's own chance of this, stated with the estimate: 45%; at least 1.4-fold (0.15 log units) between middle value and limit.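

In this assay compound 3 gives > 10000 nM, which is a limit of the assay and not a number. Cyano on this aromatic carbon therefore gives no measurable value, just as methoxycarbonyl did, and the step between these two limits cannot be read. Against acetyl, the only group here with a measured number, the result is an at least 1.6-fold higher number from compound 1 to compound 3 (0.21 log units; that floor lies within the scatter), so this change shows no difference beyond the scatter.

Going by these compounds, how far apart the three groups truly lie stays open, since the read-out stops at one limit: the limit of > 10000 nM in this assay, at which 2 of the 3 values shown sit. Also open is how an amine or a carboxylic acid on this aromatic carbon would read against compound 1.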